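The source may report more compounds than this note shows. Statements on the series, on what has been measured and on what is new or still open speak of the compounds shown alone.

In a functional assay on A549 cells (Homo sapiens) for inhibition, read by colorimetric assay and MTT assay, with a stated time of 72 h (a higher number here means a weaker inhibitor, a lower number a stronger inhibitor), compound 1 `C=CCCCCOc1ccccc1-c1cnc(OCCCCC=C)n1C` gives 7000 nM and compound 2 `C=CCCCCOc1ncc(-c2ccccc2OC)n1C` gives 5000 nM. These two values lie within the scatter of each other, so compound 2 has no real rank in this small set. Next in the series is compound 3 `C=CCCCCOc1ncc(-c2cc(Cl)ccc2OC)n1C`, which differs from compound 2 as follows: chloro in place of hydrogen on an aromatic carbon. Among the compounds with values here, only one measured step exists, a 1.4-fold lower number from compound 1 to compound 2 (0.15 log units; within the scatter). That step is small, but it concerns a different place in the molecule, so it bears only indirectly on the new change. Within the data shown here, no measured step shows the effect of chloro on this ring, and the direction remains open. No step beyond the scatter is therefore expected in this assay. The expected change is a 1.3-fold lower number from compound 2 to compound 3 (0.10 log units; within the scatter). For compound 3 the estimated value is 4000 nM, with an expected range of 1500 nM to 10000 nM.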

Compound 3, half-maximal inhibitory concentration: 34000 nM
For compound 3 the middle estimate is 8.5-fold (0.93 log units) below the measured one, outside the stated range (above it).
By their numbers in this assay, from the lowest: compounds 2 and 1 (each within the scatter of the next); then compound 3.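

In this assay, chloro in place of hydrogen on the aromatic carbon para to the methoxy group and meta to the large group gives a 6.8-fold higher number from compound 2 to compound 3 (0.83 log units; beyond the scatter). Within the data shown here, this is the first step beyond the scatter, so this position responds to a single added chlorine atom, and for chloro here the direction is now settled toward a weaker inhibitor. Nothing at hand accounts for the size or direction of this step.

The compounds shown leave open whether the loss belongs to chloro itself or would also follow from fluoro, methyl or an amine on the same carbon. They also leave open whether chloro on another carbon of this ring, or on the core of compound 1 with its second ether chain, would give a similar step.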